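Side-chain lactam swap on a diaryl urea scaffold

The source may report more compounds than this note shows. Statements on the series, on what has been measured and on what is new or still open speak of the compounds shown alone.

Compound 2 `Cc1cc(C(=O)Nc2ccc(Cl)cc2)ccc1N(CCN1CCOCC1=O)C(=O)Nc1ccc(Cl)cc1` gives the lower of the two numbers measured in an ADME assay on microsomes from liver (Homo sapiens) for metabolic stability (a higher number here means that the compound lasts longer, a lower number that the compound disappears faster), at 0.152 h. Compound 1 `Cc1cc(C(=O)Nc2ccc(Cl)cc2)ccc1N(CCN1CCCC1)C(=O)Nc1ccc(Cl)cc1` gives 3.28 h in this assay, and the step of a 22-fold lower number from compound 1 to compound 2 (1.33 log units; beyond the scatter) rests on a single change, 3-oxomorpholin-4-yl in place of pyrrolidin-1-yl on a saturated chain carbon, two bonds along the chain from an amide-type nitrogen. Compound 3 `Cc1cc(C(=O)Nc2ccc(Cl)cc2)ccc1N(CCN1CCCC1=O)C(=O)Nc1ccc(Cl)cc1` differs from compound 2 as follows: 2-oxopyrrolidin-1-yl in place of 3-oxomorpholin-4-yl on a saturated chain carbon, two bonds along the chain from an amide-type nitrogen. Going by the values given here, no measured step matches this change; the only step measured concerns a ring without a carbonyl, whereas compound 3, like compound 2, keeps one double bond outside aromatic rings and a hydrogen-bond acceptor in the ring. Compound 3 is therefore expected to remain close to compound 2, with a step of a 2.0-fold higher number from compound 2 to compound 3 (0.30 log units; within the scatter) at most slightly beyond the scatter. The estimate for compound 3 in this assay is 0.3 h, with a range from 0.12 h to 0.8 h.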

Compound 3, half-life: 0.158 h
Beside the measured number, compound 3's estimate is 1.9-fold (0.28 log units) above it, and the stated range covers the measured number.
By their numbers in this assay, from the lowest: compounds 2 and 3 (each within the scatter of the next); then compound 1.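

At this place, on a saturated chain carbon, two bonds along the chain from an amide-type nitrogen, this assay shows a 1.0-fold higher number from compound 2 to compound 3 (0.02 log units; within the scatter), so 2-oxopyrrolidin-1-yl and 3-oxomorpholin-4-yl cannot be told apart despite their different rings. Set against compound 1, 2-oxopyrrolidin-1-yl gives a 21-fold lower number from compound 1 to compound 3 (1.32 log units; beyond the scatter), a step of about the same size as a 22-fold lower number from compound 1 to compound 2 (1.33 log units; beyond the scatter), and here the five-membered ring is kept while a ring carbonyl is added to pyrrolidin-1-yl. No supporting measurement is available to explain these results. The compounds shown leave open whether morpholin-4-yl, which has the ring oxygen without the carbonyl, would stand with compound 1 or with compound 2 and compound 3. They also leave open where an open-chain acetamide or a dimethylamine on this chain would fall.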